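Benzyl on the Amide Nitrogen of Compound 2

This account rests on a few compounds, and the source may have more. Where it says the series, first, only, none or still open, it means among the compounds named here.

Among the compounds with values here, compound 2 (`CCCCNc1nc(N)nc2cccc(C(=O)NC)c12`) gives 0.39 uM in an ADME assay on HEK293 cells for agonist activity at Toll-like receptor 8 (Homo sapiens), read by a luciferase reporter, with a stated time of 6 h (a higher number here means that more compound is needed for the effect, a lower number that less compound is needed), and so holds the highest of the two numbers at hand; its only neighbour, compound 1 (`CCCCNc1nc(N)nc2cccc(OCCOC)c12`), gives 0.2 uM, and the step of a 2.0-fold higher number from compound 1 to compound 2 (0.29 log units; within the scatter) stays within the scatter. Compound 3 (`CCCCNc1nc(N)nc2cccc(C(=O)N(C)Cc3ccccc3)c12`) differs from compound 2 by benzyl in place of hydrogen on an amide-type nitrogen. Within the data shown here, no measured step touches that nitrogen: the one step on record, from compound 1 to compound 2, concerns the group on the aromatic carbon and is itself small, so it bears on the new change only by showing that the shared core tolerates a swap at its edge without a shift beyond the scatter. With nothing else to lean on, compound 3 is expected to sit close to compound 2, with a 1.3-fold higher number from compound 2 to compound 3 (0.11 log units; within the scatter) as the guess, a step of no clear direction. The estimate for compound 3 is therefore 0.5 uM, within 0.15 uM to 2 uM.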

Compound 3, minimum effective concentration: > 25 uM
Compound 3 gave a limit, no number (the forecaster's own chance of this, stated with the estimate: 10%); middle value at least 50-fold (1.69 log units) from the limit.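

The amide-type nitrogen proves far less forgiving in this assay than the earlier swap on the aromatic carbon, which stayed within the scatter: benzyl in place of hydrogen there gives an at least 64-fold higher number from compound 2 to compound 3 (1.80 log units; beyond the scatter). Compound 3 gives a limit of the assay and not a number: the limit of > 25 uM in this assay, at which 1 of the 3 values shown sits. The tolerance seen at the edge of the shared core therefore does not extend to this change, although this rests on a single pair and the full size of the step cannot be read.

From the compounds shown here alone, whether a second methyl on that nitrogen would also reach the limit, or whether benzyl would do so with the amide hydrogen kept, stays open. The compounds shown also leave open how an amine or a carboxylic acid on the benzyl ring would read.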